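The compounds below may be only part of what the source reports. "The series", "measured", "known", "first", "only" and "open" are said of these compounds alone.

In a functional assay on A549 cells (Homo sapiens) for cytotoxicity, read by MTT assay (a lower number here means a stronger inhibitor, a higher number a weaker inhibitor), three compounds sharing one core have been measured: compound 1 (`COc1ccc(OC)c(C(=O)/C=C/c2ccco2)c1`) gives 27900 nM, compound 2 (`COc1ccc(OC)c(C(=O)/C=C/c2ccoc2)c1`) gives 22100 nM and compound 3 (`COc1ccc(OC)c(C(=O)/C=C/c2cccs2)c1`) gives 11000 nM. Two steps place the last of these: a 2.5-fold lower number from compound 1 to compound 3 (0.40 log units; beyond the scatter), and a 2.0-fold lower number from compound 2 to compound 3 (0.30 log units; within the scatter). The unmeasured compound 4 (`COc1ccc(OC)c(C(=O)/C=C/c2ccsc2)c1`) carries thiophen-3-yl in place of thiophen-2-yl on a double-bonded chain carbon bound to a double-bonded chain carbon. Among the measured compounds shown here, the closest precedent is furan-3-yl in place of furan-2-yl, a 1.3-fold lower number from compound 1 to compound 2 (0.10 log units; within the scatter), so no change beyond the scatter is expected. The estimated step is a 1.1-fold lower number from compound 3 to compound 4 (0.04 log units; within the scatter). For compound 4 the expected value is 10000 nM, with an estimated range of 5000 nM to 21000 nM.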

Compound 4, half-maximal inhibitory concentration: 3800 nM
Beside the measured number, compound 4's estimate is 2.6-fold (0.42 log units) above it; measured number outside the range, below it.
By their numbers in this assay, from the lowest: compound 4; then compounds 3, 2 and 1 (each within the scatter of the next, the first and the last beyond it).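

With thiophen-3-yl in place of thiophen-2-yl on a double-bonded chain carbon bound to a double-bonded chain carbon, the attachment point of the ring proves to matter in this assay (in a 2.9-fold lower number from compound 3 to compound 4 (0.46 log units; beyond the scatter)), whereas the furan pair had shown only a step within the scatter (a 1.3-fold lower number from compound 1 to compound 2 (0.10 log units; within the scatter)). Compound 4 also stands clear of both furans (a 5.8-fold lower number from compound 2 to compound 4 (0.76 log units; beyond the scatter); a 7.3-fold lower number from compound 1 to compound 4 (0.87 log units; beyond the scatter)), making it the strongest of the four. No available evidence explains why the thiophen-3-yl group does better. As far as these compounds go, whether an amine or a carboxylic acid on the thiophen-3-yl ring would keep or extend this gain stays open.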